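Exchanging the Amide Tail of Compound 3

The source may hold more compounds than are shown below. What is called first, only, known or untested is meant among the compounds shown, and "the series" means these compounds.

Compound 1 `CC(=O)NCc1cccc(Cn2nc(NS(=O)(=O)c3ccc(Cl)s3)c3c(C(C)O)cccc32)c1`: 20 nM
Compound 2 `CC(=O)NCc1cccc(Cn2nc(NS(=O)(=O)c3ccc(Cl)s3)c3c(C(F)F)cccc32)c1`: 100 nM
Compound 3 `COc1cccc2c1c(NS(=O)(=O)c1ccc(Cl)s1)nn2Cc1cccc(CNC(=O)C2COC2)c1`: 20 nM

All three were measured in a functional assay on CHO cells for antagonist activity at C-C chemokine receptor type 4 (Homo sapiens), read by GTPgammaS binding; on this read-out higher numbers stand for weaker inhibition and lower numbers for stronger inhibition. Compound 3 stands level with compound 1, and these two together hold the lowest numbers of the three; compound 2 sits higher, as the step of a 5.0-fold higher number from compound 1 to compound 2 (0.70 log units; beyond the scatter) shows. That single measured step concerns difluoromethyl in place of 1-hydroxyethyl on an aromatic carbon and leaves the amide tail untouched. Compound 4 `COc1cccc2c1c(NS(=O)(=O)c1ccc(Cl)s1)nn2Cc1cccc(CNC(=O)C(C)(C)N)c1` differs from compound 3 by 1-amino-1-methylethyl in place of oxetan-3-yl on a carbonyl carbon. Going by the values given here, no measured step bears on this change, so the expectation rests on compound 3 alone: compound 4 is expected to stay near it, with no change at the digits printed from compound 3 to compound 4 (within the scatter). Compound 4 is therefore estimated at 20 nM, within a range of 7 nM to 60 nM.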

Compound 4, half-maximal inhibitory concentration: 15.9 nM
For compound 4 the middle estimate is 1.3-fold (0.10 log units) above the measured one, and the stated range covers the measured number.
By their numbers in this assay, from the lowest: compounds 4, 1 and 3 (each within the scatter of the next); then compound 2.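

In this assay, the step of a 1.3-fold lower number from compound 3 to compound 4 (0.10 log units; within the scatter) shows that the carbonyl carbon of the amide tail can carry either oxetan-3-yl or 1-amino-1-methylethyl with no difference the read-out can separate. At this position, then, the four-membered ring can give way to an open group that adds a hydrogen-bond donor, and the two compounds still read alike. No supporting measurement bears on why they do.

From the compounds shown here alone, whether a carboxylic acid or a longer amine chain on this carbonyl carbon would read the same remains open. So does whether either tail behaves alike with difluoromethyl on the shared core.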